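The source may hold more compounds than are shown below. What is called first, only, known or untested is meant among the compounds shown, and "the series" means these compounds.

Working notes on the series. In an assay for inhibition of inositol hexakisphosphate kinase 3 (Homo sapiens), read by colorimetric assay, coupled enzyme assay and malachite green, with a stated time of 120 min, in the presence of a further agent that is not named here (a higher number here means a weaker inhibitor, a lower number a stronger inhibitor), compound 1 `O=C(O)/C=C/c1ccc2noc(-c3ccc(Oc4ccccc4)cc3)c2c1` gives 760 nM; compound 3 `O=C(O)c1ccc2noc(-c3ccc(Oc4ccccc4)cc3)c2c1` gives 550 nM; compound 2 `Cc1cccc(-c2onc3ccc(/C=C/C(=O)O)cc23)c1` gives 3590 nM, the highest number of the three. The change from compound 1 to compound 3, (carboxy in place of 2-carboxyethenyl on an aromatic carbon), gave a 1.4-fold lower number from compound 1 to compound 3 (0.14 log units; within the scatter). The difference between the core of compound 2 and the core of compound 1 is not broken down here. Compound 4 `Cc1cccc(-c2onc3ccc(C(=O)O)cc23)c1` carries the same change on the core of compound 2: carboxy in place of 2-carboxyethenyl on an aromatic carbon. Because the measured step of a 1.4-fold lower number from compound 1 to compound 3 (0.14 log units; within the scatter) stayed within the scatter, the step from compound 2 to compound 4 is expected to be of similar size, a 1.4-fold lower number from compound 2 to compound 4 (0.14 log units; within the scatter), in this assay. Compound 4 is therefore estimated at 2600 nM, with a range from 1200 nM to 5500 nM expected in this assay.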

Compound 4, half-maximal inhibitory concentration: 1410 nM
Estimate against measurement, compound 4: 1.8-fold (0.27 log units) above; measured number inside the range.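

Carboxy in place of 2-carboxyethenyl on an aromatic carbon gave a 2.5-fold lower number from compound 2 to compound 4 (0.41 log units; beyond the scatter) in this assay. The size of this change does not differ measurably between the two cores: the same change on two cores in this assay, a 1.4-fold lower number (0.14 log units; within the scatter) from compound 1 to compound 3 and a 2.5-fold lower number (0.41 log units; beyond the scatter) from compound 2 to compound 4, 1.8-fold (0.27 log units) apart, within the scatter of two such steps. This shows agreement on two cores only; it sets no rule for other cores in the series, and it does not explain why the step lies beyond the scatter on one core and within it on the other.

Still open, going by these compounds, is whether a primary amide or a longer chain ending in carboxy, placed on that same aromatic carbon, would give steps of similar size. On these data alone, whether the change carries to a third core also remains open.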